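Methoxy on the Phenyl End of a Fused Thiourea Core

A few compounds are considered here, and "the series" means these few. Any claim that something is new, unique, unknown or untested is made for them only; others in the source may bear on it.

Compound 1 `CCN1C(=O)N(CC)C2C1NC(=S)N2/N=C/C=C/c1ccccc1` gives 36100 nM in a functional assay on MCF7 cells (Homo sapiens) for inhibition, read by MTT assay, with a stated time of 72 h; a lower number here means a stronger inhibitor, a higher number a weaker inhibitor. Compound 2 `CCN1C(=O)N(CC)C2C1NC(=S)N2/N=C/C=C/c1ccc(OC)cc1` differs from it by methoxy in place of hydrogen on an aromatic carbon, and compound 2 gives 36600 nM; the step of a 1.0-fold higher number from compound 1 to compound 2 (0.01 log units; within the scatter) is thus flat. Compound 3 `CCN1C(=O)N(c2ccccc2)C2NC(=S)N(/N=C/C=C/c3ccccc3)C21` has a different core, differing from compound 1 by phenyl in place of ethyl on an amide-type nitrogen in a ring, and compound 3 gives 2250 nM, so the step of a 16-fold lower number from compound 1 to compound 3 (1.21 log units; beyond the scatter) is the only large one seen. Compound 4 `CCN1C(=O)N(c2ccccc2)C2NC(=S)N(/N=C/C=C/c3ccccc3OC)C21` is the unmeasured partner: it differs from compound 3 by methoxy in place of hydrogen on an aromatic carbon. This is the same kind of change as from compound 1 to compound 2, yet not the same, since there the methoxy sits para to a large group and here ortho to it. Because the earlier methoxy step a 1.0-fold higher number from compound 1 to compound 2 (0.01 log units; within the scatter) stayed within the scatter, compound 4 is expected to stay close to compound 3, with an estimated step of a 1.2-fold higher number from compound 3 to compound 4 (0.06 log units; within the scatter). Compound 4 is estimated at 2600 nM, between 1000 nM and 6500 nM.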

Compound 4, half-maximal inhibitory concentration: 79100 nM
Compound 4: middle estimate off by 30-fold (1.48 log units), on the low side, outside the stated range (above it).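

In this assay, the methoxy change gives a 35-fold higher number from compound 3 to compound 4 (1.55 log units; beyond the scatter), so a change that was flat on the core of compound 1 does not carry over to the core of compound 3: the same change on two cores in this assay, a 1.0-fold higher number (0.01 log units; within the scatter) from compound 1 to compound 2 and a 35-fold higher number (1.55 log units; beyond the scatter) from compound 3 to compound 4, 35-fold (1.54 log units) apart, beyond the scatter of two such steps

This shows that the result of this change on one core cannot be assumed for the other. It does not show why, since the core and the place of the methoxy both differ between the two steps, with the methoxy ortho to a large group in compound 4 but not in compound 2.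

As far as these compounds go, it remains open what a methoxy would do on compound 3 at the ring place it holds in compound 2, and what it would do on the core of compound 1 at the place it holds in compound 4. Also open, from the compounds shown here alone, is whether a fluorine or a hydroxyl at the place of the methoxy in compound 4 would give a step of similar size.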